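This account rests on a few compounds, and the source may have more. Where it says the series, first, only, none or still open, it means among the compounds named here.

Compound 1 `C=CCc1cc(C(C)=O)c(O)cc1OCC#N` and compound 2 `CCc1cc(C(C)=O)c(O)cc1OCCCC(C)(C)C#N` share a core and were both tested in an assay on isolated protein for binding affinity to leukotriene B4 receptor 1 (Homo sapiens), tested at 1 uM; a higher number here means more inhibition at the concentration tested (going by the name of the read-out), a lower number less inhibition. In this assay compound 1 gives 2%, while compound 2 gives 46%, the higher of the two numbers, with a gap well beyond the usual scatter. Compound 3 `CCc1cc(C(C)=O)c(O)cc1OCCCCCC[S+](C)[O-]` has not been measured yet; compared with compound 2 it differs by a group of 6 heavy atoms (4 carbon, 1 oxygen, 1 sulfur; no ring) in place of a group of 5 heavy atoms (4 carbon, 1 nitrogen; no ring), on a saturated chain carbon, three bonds along the chain from an oxygen on an aromatic ring. For the measured compounds named here, no measured pair shows a change of this kind, so only a modest shift is expected, with no direction clearly favoured. The expected step is a number 8 percentage points lower from compound 2 to compound 3 (within the scatter). Compound 3 is estimated at 38%, within a range of 12% to 62%.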

Compound 3, a percentage reported as inhibition, at one concentration (the size of the read-out at that concentration, not a potency): 50%
The estimate for compound 3 lay 12 percentage points below the measured number; low and high end bracket the measured number.
By their numbers in this assay, from the lowest: compound 1; then compounds 2 and 3 (each within the scatter of the next).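

In this assay, putting the new sulfur-and-oxygen group in place of 1-cyano-1-methylethyl, on a saturated chain carbon, three bonds along the chain from an oxygen on an aromatic ring, gives a number 4 percentage points higher from compound 2 to compound 3 (within the scatter). The nitrile is therefore not required at this position to retain this level of inhibition, since a quite different group reads the same within the scatter. Nothing measured here bears on why the two groups read alike. From the compounds shown here alone, what an amine or a carboxylic acid would give at this position remains open. Compound 1 differs from compound 2 in more than one place, so its lower number cannot be tied to any single part.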